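The source may hold more compounds than are shown below. What is called first, only, known or untested is meant among the compounds shown, and "the series" means these compounds.

Measured in an ADME assay on Raji cells (Homo sapiens) for cytotoxicity, read by luminescence, with a stated time of 72 h; a lower number here means that less compound is needed, a higher number that more compound is needed for the effect:
Compound 1 `CCOC(=O)c1c(-c2cccc(OC)c2)[nH]c2cc(OC)c(OC)cc2c1=O`: > 21500 nM
Compound 2 `CCOC(=O)c1c(-c2cccc(-c3ccccc3)c2)[nH]c2cc(Cl)c(OC)cc2c1=O`: > 21500 nM

Compound 2 gives > 21500 nM, which is a limit of the assay and not a number. It sits at the limit of > 21500 nM in this assay, at which 2 of the 2 values shown sit. Compound 3 `CCOC(=O)c1c(-c2cccc(OC)c2)[nH]c2cc(Cl)c(OC)cc2c1=O` is still to be measured. It differs from compound 2 by methoxy in place of phenyl on an aromatic carbon, meta to a large group. Compound 1, which carries methoxy in that same place, also gives only a limit, > 21500 nM. No step size can be read from these two limits, so no change beyond the scatter is expected in this assay, in either direction. The expected change, a number no higher from compound 2 to compound 3 (the limit leaves the size open), is an estimate and stays within the scatter. The estimate for compound 3 is 21500 nM, with an expected range of 10000 nM to 30000 nM, and the reading will most likely be a limit again.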

Compound 3, half-maximal effective concentration: > 21500 nM
Compound 3 was reported as a limit (the forecaster's own chance of this, stated with the estimate: 85%); the middle value lies on the limit itself.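

In this assay compound 3 also gives only a limit, so no step can be read between it and compound 2 or compound 1: the limit of > 21500 nM in this assay, at which 3 of the 3 values shown sit. The compounds shown leave open whether exchanging phenyl, methoxy or chloro changes the true value in this assay at all.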